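Ethyl ester of compound 3 in the cell assay

The compounds below may be only part of what the source reports. "The series", "measured", "known", "first", "only" and "open" are said of these compounds alone.

Compound 1 `C/C=C/C(=O)Nc1ccc(Cn2nc(-c3ccc(Oc4ccccc4)cc3)cc2C(=O)O)cc1` carries a carboxylic acid on its core, and compound 2 `C/C=C/C(=O)Nc1ccc(Cn2nc(-c3ccc(Oc4ccccc4)cc3)cc2C(=O)OCC)cc1` is the corresponding ester, the change being (ethyl in place of hydrogen on an oxygen next to a carbonyl group). In a functional assay on Maver1 cells (Homo sapiens) for inhibition, read by luminescence and CellTiter-Glo, with a stated time of 72 h (on this read-out higher numbers stand for weaker inhibition and lower numbers for stronger inhibition), compound 1 gives > 60000 nM, which is a limit of the assay and not a number. In this assay compound 2 gives > 60000 nM, again a limit. The step that the two limits leave unreadable from compound 1 to compound 2 is accordingly of unknown size, as both values sit at the limit of > 60000 nM in this assay, at which 3 of the 3 values shown sit.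

Compound 3 `C=CC(=O)N1CCCC(n2nc(-c3ccc(Oc4ccccc4)cc3)cc2C(=O)O)C1` has a different core from compound 1; the difference between the two cores is not broken down here. In this assay compound 3 gives > 60000 nM, once more a limit. Compound 4 `C=CC(=O)N1CCCC(n2nc(-c3ccc(Oc4ccccc4)cc3)cc2C(=O)OCC)C1` has not yet been measured. Within the data shown here, it differs from compound 3 by ethyl in place of hydrogen on an oxygen next to a carbonyl group, which is the same change, at the same place, as the one from compound 1 to compound 2.

The measured pair gives no readable size for this change, and all three values shown sit at the limit of > 60000 nM in this assay, at which 3 of the 3 values shown sit, so there is no measured basis for placing compound 4 anywhere else. The expected step is a step that the limit leaves unreadable from compound 3 to compound 4, an expectation that rests on compound 3 standing at > 60000 nM, a limit. Compound 4 is therefore expected at 80000 nM in this assay, within 20000 nM to 300000 nM, and most probably reported only as a limit.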

Compound 4, half-maximal inhibitory concentration: > 60000 nM
Compound 4 was reported as a limit (the forecaster's own chance of this, stated with the estimate: 85%); the middle value does not contradict the limit.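

Both compound 3 and compound 4 stand at limits in this assay and not at numbers, so no new step can be read between them. The compounds shown leave open whether ethyl in place of hydrogen on an oxygen next to a carbonyl group changes inhibition at all, because none of them gives a number: the limit of > 60000 nM in this assay, at which 4 of the 4 values shown sit.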